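The compounds below may be only part of what the source reports. "The series", "measured", "known", "first", "only" and "open" are said of these compounds alone.

The series is built around a shared core carrying an acrylamide and a triazine-linked aniline bearing a further aryl substituent. In a functional assay on Ramos cells (Homo sapiens) for antiproliferative activity, read by CCK-8 assay, with a stated time of 24 h (on this read-out higher numbers stand for weaker inhibition and lower numbers for stronger inhibition), compound 1 `C=CC(=O)Nc1cccc(Nc2nc(N)nc(Nc3ccc(Oc4ccccc4)cc3)n2)c1` gives 20000 nM, a weak result. Compound 2 `C=CC(=O)Nc1cccc(Nc2ncnc(Nc3ccc(C(=O)Nc4ccccn4)cc3)n2)c1` has no result in this assay, its entry reading "not determined" (no result reported), and compound 3 `C=CC(=O)N1CCc2ccc(Nc3ncnc(Nc4ccc(C(=O)N5CCCCC5)cc4)n3)cc21` likewise has no result there, its entry reading "not determined" (no result reported), so compound 2 stands without a number and the only measured point among the three is compound 1. Compound 4 `C=CC(=O)Nc1cccc(Nc2ncnc(Nc3ccc(-c4ccc(Cl)nc4)cc3)n2)c1` differs from compound 2 in one place: 6-chloropyridin-3-yl in place of (pyridin-2-yl)carbamoyl on an aromatic carbon. Going by the values given here, no measured pair shows how such a change moves this assay, and compound 2 itself offers no value to step from, so any step from compound 2 to compound 4 cannot be sized; the single result for compound 1 only suggests the series sits in the weakly active range. Compound 4 is therefore expected to give about 5000 nM in this assay, with a plausible range from 800 nM to 30000 nM, an estimate resting on compound 1 alone.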

Compound 4, half-maximal inhibitory concentration: 160000 nM
Beside the measured number, compound 4's estimate is 32-fold (1.51 log units) below it; measured number above the stated range.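

In this assay, going by these compounds alone, compound 4 gives 160000 nM, but compound 2 carries no number there, so no step between the two can be read. On these data alone, how replacing (pyridin-2-yl)carbamoyl with 6-chloropyridin-3-yl moves this read-out stays open. Nothing shown accounts for the result for compound 4.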